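This account rests on a few compounds, and the source may have more. Where it says the series, first, only, none or still open, it means among the compounds named here.

Measured so far:
- compound 1, `Cc1ccc(-c2c(S(=O)(=O)c3ccccc3)cnc3cc(C)nn23)cc1`: 8.1%
- compound 2, `O=S(=O)(c1ccccc1)c1cnc2cc(-c3ccc(Cl)cc3)nn2c1-c1ccc(Br)cc1`: 13.8%
- compound 3, `Cc1ccc(-c2c(S(=O)(=O)c3ccccc3)cnc3ncnn23)cc1`: 2.4%

All three compounds were tested in a functional assay on the whole organism for inhibition, with Mus musculus as the target, with a stated time of 5 h, at a dose of 50 mg/kg by the oral route; a higher number here means more inhibition at the dose given (going by the name of the read-out), a lower number less inhibition. Compound 3 stands at the low end of the three numbers. Its gap to compound 1 lies within the usual scatter of repeated measurements, so the two cannot be told apart on these figures. Compound 2 lies beyond that scatter, on the higher side, but compound 2 also carries a different core and a further aryl group, so no single change separates it from compound 3.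

The next compound, compound 4 (`O=S(=O)(c1ccccc1)c1cnc2ncnn2c1-c1ccc(Br)cc1`), keeps the core of compound 3 and alters one group: bromo in place of methyl on an aromatic carbon. Among the compounds with values here, no pair of measured compounds differs only in this way, so there is no measured step to lean on. Compound 2, which also carries a bromophenyl, gives a higher number, but its other differences from compound 3 make this weak ground.

Given that, the expected step from compound 3 to compound 4 in this assay is small, a number 4.6 percentage points higher from compound 3 to compound 4 (within the scatter), and is not expected to rise beyond the scatter. Compound 4 is therefore estimated at 7% in this assay, within a range of -3% to 22%.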

Compound 4, a percentage reported as inhibition, in the whole organism at one dose (the size of the read-out at that dose, not a potency): 0.8%
Compound 4: the middle estimate sits 6.2 percentage points above what was measured; low and high end bracket the measured number.
By their numbers in this assay, from the lowest: compounds 4, 3, 1 and 2 (each within the scatter of the next, the first and the last beyond it).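

In this assay, within the data shown here, the swap of methyl for bromo, on an aromatic carbon para to a large group, gives the first comparison here in which only one place differs: a number 1.6 percentage points lower from compound 3 to compound 4 (within the scatter) for this change. On this core, then, the 4-methylphenyl and 4-bromophenyl compounds cannot be told apart, and the higher number of compound 2, which also carries a bromophenyl, cannot be credited to the bromo group, since compound 4 has that group and compound 4 gives only 0.8% in this assay. No measurement is available that could explain why the two compounds read alike.

As far as these compounds go, because both numbers are so small, this single pair cannot show whether the position matters in general, and it remains open whether an amine, a carboxylic acid or a longer chain at this place would move the number beyond the scatter. From the compounds shown here alone, it is also open whether the same swap would read alike on the core of compound 1, where a methyl group sits on the ring system in place of the core of compound 3.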